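The source may hold more compounds than are shown below. What is called first, only, known or untested is meant among the compounds shown, and "the series" means these compounds.

Measured in an ADME assay on SW480 cells (Homo sapiens) for cytotoxicity, read by MTT assay, with a stated time of 72 h; on this read-out higher numbers stand for weaker inhibition and lower numbers for stronger inhibition:

- compound 1 `CCOc1ccc(NC(=O)c2cccc(/C=C3\CC(=O)N(c4ccccc4)C3=O)c2)cc1` gives 91500 nM
- compound 3 `CCc1cccc(NC(=O)c2cccc(/C=C3\CC(=O)N(Cc4ccccc4)C3=O)c2)c1` gives 91500 nM
- compound 2 `CCCCCN1C(=O)C/C(=C\c2cccc(C(=O)Nc3cccc(F)c3)c2)C1=O` gives only a limit of the assay, > 100000 nM

Compound 1 and compound 3 stand level at the digits shown; their two values lie within the scatter, so no order between them is claimed. For compound 2 the read-out is a limit and not a number, as in the limit of > 100000 nM in this assay, at which 1 of the 3 values shown sits. All measured members of the series thus sit at the weak end of the range this assay resolves.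

Compound 4 `O=C(Nc1ccc(F)cc1)c1cccc(/C=C2\CC(=O)N(c3ccccc3)C2=O)c1` differs from compound 1 in one place: fluoro in place of ethoxy on an aromatic carbon. Within the data shown here, no measured pair isolates this change, so its size has to be estimated without a direct precedent. Given that compound 1 gives 91500 nM and compound 3, carrying a different substituent on that ring, gives the same digits, the step from compound 1 to compound 4 in this assay is expected to be small, a 1.0-fold lower number from compound 1 to compound 4 (0.01 log units; within the scatter), none beyond the scatter in either direction. Compound 4 is therefore expected near 90000 nM, within a range from 40000 nM to 200000 nM, with a real chance that the assay reports a limit instead of a number.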

Compound 4, half-maximal inhibitory concentration: > 100000 nM
Compound 4 gave a limit, no number; the forecaster's own chance of this, stated with the estimate: 40%; at least 1.1-fold (0.04 log units) between middle value and limit.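

Fluoro in place of ethoxy, on the aromatic carbon para to a large group, gives the first single-place step in the series: in this assay it reads as an at least 1.0-fold higher number from compound 1 to compound 4 (0.03 log units; that floor lies within the scatter). Compound 4 gives a limit, not a number: > 100000 nM. The step is therefore only a floor, it shows no change beyond the scatter, and the same limit now recurs in the series: the limit of > 100000 nM in this assay, at which 2 of the 4 values shown sit.

A step ending at a limit does not separate a real loss on going from 4-ethoxyphenyl to 4-fluorophenyl from no change at all. Open too, from the compounds shown here alone, is how an amine or a carboxylic acid at this position would read in this assay, and whether either would give a number clear of the weak end of the range.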